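Removing a fluorine from a tetrachloro hydrazone hydrazide series

A few compounds are considered here, and "the series" means these few. Any claim that something is new, unique, unknown or untested is made for them only; others in the source may bear on it.

Three compounds share a tetrachlorinated five-membered core and differ only in the group attached through the hydrazone nitrogen. Compound 1 `O=C(NN=C1C(Cl)=C(Cl)C(Cl)=C1Cl)c1ccccc1`, compound 2 `Fc1cccc(NN=C2C(Cl)=C(Cl)C(Cl)=C2Cl)c1` and compound 3 `Cc1ccc(C(=O)N(N=C2C(Cl)=C(Cl)C(Cl)=C2Cl)C(=O)c2ccc(C)cc2)cc1` were tested in a functional assay on RPMI-8226 cells (Homo sapiens) for cytotoxicity, read by MTT assay, with a stated time of 48 h; on this read-out lower numbers stand for stronger inhibition and higher numbers for weaker inhibition. Compound 1 gives 600 nM, compound 2 gives 500 nM and compound 3 gives 500 nM. These three numbers lie within the usual scatter of one another, so none can be ranked against the others. Compound 4 `ClC1=C(Cl)C(Cl)=C(Cl)C1=NNc1ccccc1` has not been measured in this assay. The change from compound 2 to compound 4 is hydrogen in place of fluoro on an aromatic carbon. Since the three measured variations leave the number essentially unchanged, the step expected here a 1.2-fold higher number from compound 2 to compound 4 (0.08 log units; within the scatter) is none beyond the scatter. Compound 4 is therefore expected to give about 600 nM, with a likely range from 300 nM to 1200 nM.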

Compound 4, half-maximal inhibitory concentration: 600 nM
Compound 4: the middle estimate sits on the measured number at the digits printed, within the range that was stated.
By their numbers in this assay, from the lowest: compounds 2, 3, 1 and 4 (each within the scatter of the next).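

Among these compounds, compound 2 and compound 4 form the only pair here that differs in one place, so the fluoro group can be judged on its own. In this assay the swap to hydrogen on this aromatic carbon, meta to a large group, gives a step within the scatter (a 1.2-fold higher number from compound 2 to compound 4 (0.08 log units; within the scatter)), so the fluoro group is not needed to hold the number at this place. Nothing measured here explains this outcome.

From the compounds shown here alone, whether an amine, a carboxylic acid or a longer chain at this same place would move the number remains open.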